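Cytotoxicity notes: opening the cyclopentyl amide of compound 1

The compounds below may be only part of what the source reports. "The series", "measured", "known", "first", "only" and "open" are said of these compounds alone.

Compound 1 `CCCC(=O)OCSc1ccccc1C(=O)NC1(C(N)=O)CCCC1` is read in an ADME assay on CEM-SS cells (Homo sapiens) for cytotoxicity, read by XTT assay, with a stated time of 6 days; a lower number here means that less compound is tolerated, a higher number that more compound is tolerated. In this assay compound 1 gives > 100 uM, which is a limit of the assay rather than a number (the limit of > 100 uM in this assay, at which 1 of the 3 values shown sits). Compound 2 `CCCC(=O)OCSc1ccccc1C(=O)NCCCCNC(C)=O` gives 17.4 uM and compound 3 `CCCC(=O)OCSc1ccccc1C(=O)N[C@@H]1CCC[C@H]1C(N)=O` gives 43.7 uM in this assay. Both changes away from compound 1 lowered the number: an at least 5.7-fold lower number from compound 1 to compound 2 (0.75 log units; beyond the scatter) and an at least 2.2-fold lower number from compound 1 to compound 3 (0.35 log units; beyond the scatter); between the two, a 2.5-fold higher number from compound 2 to compound 3 (0.40 log units; beyond the scatter).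

Compound 4 `CCCC(=O)OCSc1ccccc1C(=O)NCC(=O)NCC(N)=O` is not yet measured. It differs from compound 1 by ((carbamoylmethyl)carbamoyl)methyl in place of 1-carbamoylcyclopentyl on an amide-type nitrogen. As in compound 2, the ring at this nitrogen is given up for an open chain, and the step from compound 1 to compound 2 is the closest guide. A lower number than for compound 1 is therefore expected in this assay, of a size comparable to those two measured steps. The expected step is an at least 2.8-fold lower number from compound 1 to compound 4 (0.45 log units; beyond the scatter), and compound 4 is estimated at 35 uM with a range from 10 uM to 150 uM.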

Compound 4, half-maximal toxic concentration: > 100 uM
Compound 4 gave a limit, no number (the forecaster's own chance of this, stated with the estimate: 30%); at least 2.8-fold (0.45 log units) between middle value and limit.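

In this assay compound 4 gives > 100 uM, which is a limit of the assay, and the step from compound 1 cannot be read: the limit of > 100 uM in this assay, at which 2 of the 4 values shown sit.

Giving up the ring on the amide-type nitrogen does not of itself lower the number, which compound 2 alone could not show: the series has an at least 5.7-fold higher number from compound 2 to compound 4 (0.75 log units; beyond the scatter) and an at least 2.2-fold higher number from compound 3 to compound 4 (0.35 log units; beyond the scatter). The two open chains, compound 2 and compound 4, therefore part ways in this assay, and the ((carbamoylmethyl)carbamoyl)methyl group leaves compound 4 at the same limit as compound 1.

No order can be stated between compound 1 and compound 4. Also open, from the compounds shown here alone, is whether a carboxylic acid in place of the carbamoyl of this group, or a longer chain of the same kind, would stay at this limit.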